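Working notes: the step from compound 1 to compound 4

The compounds below may be only part of what the source reports. "The series", "measured", "known", "first", "only" and "open" are said of these compounds alone.

Measured in an ADME assay on cells (Lymphocyte, Homo sapiens) for cytotoxicity, read by MTT assay, with a stated time of 48 h; a lower number here means a stronger inhibitor, a higher number a weaker inhibitor:
- compound 1 `COC(=O)/C(=C\c1ccc(OC(=O)c2ccccc2)cc1)Sc1ccnc2cc(Cl)ccc12`: > 100000 nM (a limit)
- compound 2 `COC(=O)/C(=C\c1ccc(OC(=O)c2cccc(OC)c2)cc1)Sc1ccnc2cc(Cl)ccc12`: > 100000 nM (a limit)
- compound 3 `COC(=O)/C(=C\c1ccc(OC(=O)c2cc(OC)cc(OC)c2)cc1)Sc1ccnc2cc(Cl)ccc12`: 84100 nM

Compound 1 stands at a limit of this assay, > 100000 nM, so no number is known for it. That value is the limit of > 100000 nM in this assay, at which 2 of the 3 values shown sit.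

Compound 4 `COC(=O)/C(=C\c1ccc(OC(=O)c2ccc(OC)cc2OC)cc1)Sc1ccnc2cc(Cl)ccc12` carries 2,4-dimethoxyphenyl in place of phenyl on a carbonyl carbon.

Going by the values given here, three measured steps bear on this change. The closest is an at least 1.1-fold lower number from compound 1 to compound 3 (0.07 log units; that floor lies within the scatter), which puts 3,5-dimethoxyphenyl in place of phenyl on the same carbonyl carbon. A single methoxy in place of hydrogen gives a step that the two limits leave unreadable from compound 1 to compound 2. The next methoxy gives an at least 1.1-fold lower number from compound 2 to compound 3 (0.07 log units; that floor lies within the scatter). None of these shows a change beyond the scatter. Compound 3 alone has a measured number, 84100 nM. On that basis, only a small step toward a lower number is expected in this assay, possibly none beyond the scatter, and a reading at the limit would be no surprise. The estimated step is an at least 1.1-fold lower number from compound 1 to compound 4 (0.04 log units; that floor lies within the scatter). Compound 4 is expected at 90000 nM, with an estimated range of 50000 nM to 160000 nM.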

Compound 4, half-maximal inhibitory concentration: 41600 nM
For compound 4 the middle estimate is 2.2-fold (0.34 log units) above the measured one, outside the stated range (below it).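

In this assay, 2,4-dimethoxyphenyl on this carbonyl carbon gives a readable change where the earlier substitutions did not, with an at least 2.4-fold lower number from compound 1 to compound 4 (0.38 log units; beyond the scatter). The arrangement of the methoxy groups on this ring therefore counts and not only their presence: 2,4-dimethoxyphenyl and 3,5-dimethoxyphenyl differ in arrangement alone, and the swap gives a 2.0-fold lower number from compound 3 to compound 4 (0.31 log units; beyond the scatter). The same direction holds in an at least 2.4-fold lower number from compound 2 to compound 4 (0.38 log units; beyond the scatter), so the 2,4-dimethoxyphenyl compound separates from all three earlier compounds in this assay, though every value remains high on the scale shown.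

The full size of the steps from compound 1 and compound 2 stays open, since each of these compounds rests on a limit and gives only a floor: the limit of > 100000 nM in this assay, at which 2 of the 4 values shown sit. Also open is whether either methoxy of the 2,4-dimethoxyphenyl group carries the step on its own, and whether a different group on this ring, such as an amine or a carboxylic acid, would move the number further in this assay.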